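A few compounds are considered here, and "the series" means these few. Any claim that something is new, unique, unknown or untested is made for them only; others in the source may bear on it.

Measured so far in an assay on HEK293 cells for displacement of a labelled ligand from corticotropin-releasing factor receptor 1 (Homo sapiens), read by scintillation counting, with a stated time of 2 h; on this read-out lower numbers stand for stronger inhibition and higher numbers for weaker inhibition:
compound 1 `CCc1nn2c(-c3c(OC)cccc3OC)cccc2c1N(CC1CCOCC1)CC1CC1` gives 105 nM
compound 2 `COCc1cc(OC)c(-c2cccc3c(N(CC4CCOCC4)CC4CC4)c(OC)nn23)c(OC)c1` gives 51 nM

Compound 1 stands at the higher of the two numbers; compound 2 gives the lower number, and the gap between them lies beyond the usual scatter. Within the data shown here, no step between measured compounds that differ in one place is available, so the change from compound 1 to compound 3 has no direct precedent.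

Compound 3 `CCc1nn2c(-c3c(C)cc(C)cc3OC)cccc2c1N(CC1CCOCC1)CC1CC1` differs from compound 1 by one change: 2-methoxy-4,6-dimethylphenyl in place of 2,6-dimethoxyphenyl on an aromatic carbon. Whether the loss of one methoxy group on this aryl ring matters in this assay cannot be read from compounds 1 and 2, which differ in several places at once.

The expected step of a 1.5-fold lower number from compound 1 to compound 3 (0.18 log units; within the scatter) is small, toward a somewhat lower number, and may well fall within the scatter. Compound 3 is estimated at 70 nM, with a range from 25 nM to 250 nM.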

Compound 3, half-maximal inhibitory concentration: 22 nM
The estimate for compound 3 lay 3.2-fold (0.50 log units) above the measured number, outside the stated range (below it).
By their numbers in this assay, from the lowest: compound 3; then compound 2; then compound 1.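

In this assay, 2-methoxy-4,6-dimethylphenyl in place of 2,6-dimethoxyphenyl gives a 4.8-fold lower number from compound 1 to compound 3 (0.68 log units; beyond the scatter), so this aryl group, on an aromatic carbon next to the ring nitrogen, is a place on the core of compound 1 where a single change moves the number beyond the scatter. The second methoxy group of compound 1 is thus not needed to reach the lower number, provided the two methyl groups are present. Nothing measured here bears on the reason for this step.

From the compounds shown here alone, the swap of a methoxy group for a methyl group cannot be separated from the added methyl group, and whether a chloro, ethoxy or dimethylamino group on this aryl ring would lower the number further stays open. Compound 2 differs from compound 1 and compound 3 in several places, so steps to it cannot be read.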